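Replacing 4-Bromophenyl in Compound 3 with 2,3-Dimethoxyphenyl

The source may report more compounds than this note shows. Statements on the series, on what has been measured and on what is new or still open speak of the compounds shown alone.

In a functional assay on A2780 cells (Homo sapiens) for antiproliferative activity, read by resazurin assay, with a stated time of 72 h (on this read-out higher numbers stand for weaker inhibition and lower numbers for stronger inhibition), compound 3 `CN(Cc1ccc(Br)cc1)C(=O)c1cc2c(Cc3ccccc3)n[nH]c2cc1O` gives 2800 nM. Compound 1 `CN(Cc1cccc(F)c1)C(=O)c1cc2c(Cc3ccccc3)n[nH]c2cc1O` gives 5000 nM, and compound 2 `CN(Cc1cccc(Br)c1)C(=O)c1cc2c(Cc3ccccc3)n[nH]c2cc1O` gives 7100 nM. These numbers show a 2.5-fold lower number from compound 2 to compound 3 (0.40 log units; beyond the scatter), but only a 1.8-fold lower number from compound 1 to compound 3 (0.25 log units; within the scatter), so compound 3 stands clearly apart from just one of the others. Compound 4 `COc1cccc(CN(C)C(=O)c2cc3c(Cc4ccccc4)n[nH]c3cc2O)c1OC`, not yet measured, carries 2,3-dimethoxyphenyl in place of 4-bromophenyl (2,3-dimethoxyphenyl in place of 4-bromophenyl on a saturated chain carbon bound to an amide-type nitrogen). Going by the values given here, no measured compound holds this group, so the only guides are the earlier swaps at the same place. One of them, a 1.4-fold higher number from compound 1 to compound 2 (0.15 log units; within the scatter), also stayed small. Only compound 2, at 7100 nM, hints that leaving 4-bromophenyl may raise the number. A small rise is therefore expected, a 1.8-fold higher number from compound 3 to compound 4 (0.25 log units; within the scatter). Compound 4 is estimated at 5000 nM, with an expected range from 1800 nM to 14000 nM.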

Compound 4, half-maximal inhibitory concentration: 4800 nM
Compound 4: middle estimate off by 1.0-fold (0.02 log units), on the high side; measured number inside the range.
By their numbers in this assay, from the lowest: compounds 3, 4, 1 and 2 (each within the scatter of the next, the first and the last beyond it).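

In this assay the new group gives a 1.7-fold higher number from compound 3 to compound 4 (0.23 log units; within the scatter) and a 1.5-fold lower number from compound 2 to compound 4 (0.17 log units; within the scatter) and also a 1.0-fold lower number from compound 1 to compound 4 (0.02 log units; within the scatter) with all three steps inside the scatter. So at this position, on a saturated chain carbon bound to an amide-type nitrogen, a ring with two methoxy groups and no halogen gives numbers that cannot be told apart from those of each of the three halogen-bearing compounds. No measurement shown here explains this. From the compounds shown here alone, whether an amine or a carboxylic acid on this ring, or a longer chain in its place, would move the number beyond the scatter remains open.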